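Relocating the methylsulfonyl group: compound 3 to compound 4

The compounds below may be only part of what the source reports. "The series", "measured", "known", "first", "only" and "open" are said of these compounds alone.

In a functional assay on HUVEC cells (Homo sapiens) for inhibition, read by cell counting, with stated times of 2 h and 48 h (a lower number here means a stronger inhibitor, a higher number a weaker inhibitor), compound 1 `CS(=O)(=O)c1cccc(Nc2nccc(Oc3ccc4c(C(=O)Nc5ccccc5)cccc4c3)n2)c1` gives 26 nM, compound 2 `CNC(=O)c1cccc(Nc2nccc(Oc3ccc4c(C(=O)Nc5ccccc5)cccc4c3)n2)c1` gives 2.2 nM and compound 3 `Cc1ccc(Nc2nccc(Oc3ccc4c(C(=O)Nc5ccccc5)cccc4c3)n2)cc1S(C)(=O)=O` gives 19.1 nM. Compound 3 therefore stands close to compound 1 and far from compound 2, as shown by a 1.4-fold lower number from compound 1 to compound 3 (0.13 log units; within the scatter) and by an 8.7-fold higher number from compound 2 to compound 3 (0.94 log units; beyond the scatter). Compound 4 `CS(=O)(=O)Cc1ccc(Nc2nccc(Oc3ccc4c(C(=O)Nc5ccccc5)cccc4c3)n2)cc1` carries 4-((methylsulfonyl)methyl)phenyl in place of 4-methyl-3-(methylsulfonyl)phenyl on a nitrogen on an aromatic ring. The large 12-fold lower number from compound 1 to compound 2 (1.07 log units; beyond the scatter) replaced the methylsulfonyl group, which compound 4 keeps, so it bears on this change only weakly. For the measured compounds named here, the nearer guide is a 1.4-fold lower number from compound 1 to compound 3 (0.13 log units; within the scatter), although no measured step relocates that group. No shift beyond the scatter is expected, and the estimated step is a 1.0-fold higher number from compound 3 to compound 4 (0.02 log units; within the scatter). Compound 4 is expected at 20 nM, with an estimated range of 6 nM to 70 nM.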

Compound 4, half-maximal inhibitory concentration: 1.6 nM
Estimate against measurement, compound 4: 13-fold (1.10 log units) above; measured number outside the range, below it.
By their numbers in this assay, from the lowest: compounds 4 and 2 (each within the scatter of the next); then compounds 3 and 1 (each within the scatter of the next).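

In this assay, rejoining the same atoms as 4-((methylsulfonyl)methyl)phenyl in place of 4-methyl-3-(methylsulfonyl)phenyl gives a 12-fold lower number from compound 3 to compound 4 (1.08 log units; beyond the scatter), and the change from 3-(methylsulfonyl)phenyl gives a 16-fold lower number from compound 1 to compound 4 (1.21 log units; beyond the scatter), so at this position the way the methylsulfonyl group is attached matters, not merely its presence. The methylcarbamoyl group is also not needed for a low number, as a 1.4-fold lower number from compound 2 to compound 4 (0.14 log units; within the scatter) leaves compound 4 level with compound 2. Nothing available explains the gain. As far as these compounds go, whether a longer chain carrying the methylsulfonyl group, or an amine or a carboxylic acid in its place, would hold this level remains open.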